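Dropping the nitro group from a weakly active macrocycle

A few compounds are considered here, and "the series" means these few. Any claim that something is new, unique, unknown or untested is made for them only; others in the source may bear on it.

Compound 1 `O=[N+]([O-])c1ccc(COc2ccc(Nc3ncnc4cc5c(cc34)OCCOCCO5)cc2)cc1` carries a nitro group on its benzyloxy arm. In a functional assay on SH-SY5Y cells (Homo sapiens) for antiproliferative activity, read by MTT assay, with a stated time of 72 h (on this read-out lower numbers stand for stronger inhibition and higher numbers for weaker inhibition), compound 1 gives 55200 nM, the highest of the three numbers recorded. Compound 2 `c1ccc(COc2ccccc2Nc2ncnc3cc4c(cc23)OCCOCCOCCOCCO4)cc1` gives 24000 nM in this assay, and compound 3 `c1ccc(COc2ccc(Nc3ncnc4cc5c(cc34)OCCOCCOCCO5)cc2)cc1` gives 23900 nM; both stand apart from compound 1 by more than the scatter, while their own two values lie within it of each other. Compound 4 `c1ccc(COc2ccc(Nc3ncnc4cc5c(cc34)OCCOCCO5)cc2)cc1` has not been measured. It differs from compound 1 by hydrogen in place of nitro on an aromatic carbon. No single-change comparison is available to show what this swap does. An expected modest move toward lower numbers, a step from compound 1 to compound 4 of a 2.0-fold lower number from compound 1 to compound 4 (0.29 log units; within the scatter), gives an estimate for compound 4 of 28000 nM, with a range from 10000 nM to 80000 nM.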

Compound 4, half-maximal inhibitory concentration: 39300 nM
Estimate against measurement, compound 4: 1.4-fold (0.15 log units) below, and the stated range covers the measured number.
By their numbers in this assay, from the lowest: compounds 3, 2, 4 and 1 (each within the scatter of the next, the first and the last beyond it).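

In this assay, within the data shown here, hydrogen in place of nitro gives a 1.4-fold lower number from compound 1 to compound 4 (0.15 log units; within the scatter), the first single-change comparison at this position of the benzyloxy arm. That step lies within the scatter, so this pair shows no difference that can be told apart from the variation between repeated measurements. Nothing available here bears on the reason for this result.

On these data alone, it remains open whether another group at this position, such as an amine or a carboxylic acid, would shift the number beyond the scatter. As far as these compounds go, it is also open whether the same swap would read the same on the macrocycle of compound 3.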